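This account rests on a few compounds, and the source may have more. Where it says the series, first, only, none or still open, it means among the compounds named here.

Measured compounds:
Compound 1 `O=c1[nH]cc(S(=O)(=O)Nc2ccccc2-c2cn(-c3ccccc3)nn2)c(=O)[nH]1` gives > 100000 nM in an ADME assay on GES1 cells (Homo sapiens) for cytotoxicity, read by MTT assay, with a stated time of 24 h; a lower number here means that less compound is tolerated, a higher number that more compound is tolerated.
Compound 2 `O=c1[nH]cc(S(=O)(=O)Nc2ccccc2-c2cn(-c3ccccc3Cl)nn2)c(=O)[nH]1` gives 20800 nM.
Compound 3 `Cc1cccc(-n2cc(-c3ccc(NS(=O)(=O)c4c[nH]c(=O)[nH]c4=O)cc3)nn2)c1` gives 28300 nM.

The value of compound 1 is a limit of this assay, not a number (the limit of > 100000 nM in this assay, at which 1 of the 3 values shown sits). Compound 3 sits close to compound 2, within the scatter. Compound 4 `O=c1[nH]cc(S(=O)(=O)Nc2ccc(-c3cn(-c4cccc(Cl)c4)nn3)cc2)c(=O)[nH]1` differs from compound 3 by chloro in place of methyl on an aromatic carbon. Among the measured compounds shown here, the only measured step with a chloro entering, an at least 4.8-fold lower number from compound 1 to compound 2 (0.68 log units; beyond the scatter), gave a lower number, but there the chloro replaced hydrogen, not methyl. For compound 4 a step of a 1.4-fold lower number from compound 3 to compound 4 (0.15 log units; within the scatter) is therefore expected, a small lowering that may well stay within the scatter. Compound 4 is estimated at 20000 nM, between 8000 nM and 50000 nM.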

Compound 4, half-maximal cytotoxic concentration: 7570 nM
For compound 4 the middle estimate is 2.6-fold (0.42 log units) above the measured one, and the stated range ends above it.
By their numbers in this assay, from the lowest: compound 4; then compounds 2 and 3 (each within the scatter of the next). At a limit, above all of these: compound 1.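

Going from 3-methylphenyl to 3-chlorophenyl is not a neutral swap in this assay: it gives a 3.7-fold lower number from compound 3 to compound 4 (0.57 log units; beyond the scatter). Until now, a chloro had been seen to lower the number only where it replaced hydrogen, and that step started from a limit; here it replaces methyl, and both values are true numbers. Both steps with a chloro entering therefore point the same way, and no compound shown goes against this, though nothing shown accounts for the size of the step. The compounds shown leave open how an amine or a carboxylic acid at this position would read. They also leave open where the plain phenyl on this same core would stand.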